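Aryl urea series: methoxy replacing trifluoromethyl

This account rests on a few compounds, and the source may have more. Where it says the series, first, only, none or still open, it means among the compounds named here.

Compound 2 `C[C@H](NC(=O)Nc1ccccc1C(F)(F)F)c1ccccc1` gives 97% in an ADME assay on the whole organism with Oryza sativa as the target, tested at 10 uM; on this read-out higher numbers stand for a weaker effect at the one concentration tested and lower numbers for a stronger effect. For the measured compounds named here, the only other measured compound, compound 1 `Cc1ccccc1NC(=O)N[C@@H](C)c1ccccc1`, gives 99% in this assay, and the step of a number 2 percentage points lower from compound 1 to compound 2 (within the scatter) is within the scatter, so the two values cannot be ordered. Compound 3 `COc1ccccc1NC(=O)N[C@@H](C)c1ccccc1` differs from compound 2 by methoxy in place of trifluoromethyl on an aromatic carbon. Going by the values given here, the single measured step is the only precedent that bears on this change: it exchanged one group on the same aromatic carbon for another and left this assay essentially unchanged, at a number 2 percentage points lower from compound 1 to compound 2 (within the scatter). Among the compounds with values here, no measured step involves a methoxy group, so the precedent is indirect. Given that both measured values sit near the top of the scale, no step beyond the scatter is expected from compound 2 to compound 3 in this assay. The estimated step is no change at the digits printed from compound 2 to compound 3 (within the scatter). Compound 3 is expected to give 97%, with a range from 87% to 100%.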

Compound 3, a percentage reported as activity, at one concentration (the size of the read-out at that concentration, not a potency): 95%
Estimate against measurement, compound 3: 2 percentage points above; the range from low to high includes it.
By their numbers in this assay, from the lowest: compounds 3, 2 and 1 (each within the scatter of the next).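

Methoxy on this aromatic carbon gives a number 2 percentage points lower from compound 2 to compound 3 (within the scatter) in this assay, and set against methyl the same position gives a number 4 percentage points lower from compound 1 to compound 3 (within the scatter). Methyl, trifluoromethyl and methoxy therefore cannot be told apart in this read-out, and the step to methoxy, the one group of the three that carries a hydrogen-bond acceptor, stays within the scatter, which extends the flat picture beyond the single earlier step. No measurement is at hand that would account for this flat result.

From the compounds shown here alone, what an amine or a carboxylic acid on this aromatic carbon would do remains open, as does whether any group here can move the read-out beyond the scatter. Also open, going by these compounds, is whether a change elsewhere on the shared core would do so.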